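A few compounds are considered here, and "the series" means these few. Any claim that something is new, unique, unknown or untested is made for them only; others in the source may bear on it.

Three related compounds have been examined in a functional assay on NCI-H460 cells (Homo sapiens) for inhibition, read by MTT assay, with a stated time of 72 h; on this read-out lower numbers stand for stronger inhibition and higher numbers for weaker inhibition. Compound 1 `CN(C)C(=S)SCC(CSC(=S)N(C)C)C(=O)c1ccccc1` gives 1930 nM in this assay. Compound 2 `CN(C)C(=S)SCC(CSC(=S)N(C)C)C(=O)c1ccc(F)cc1`, which carries a fluoro on an aromatic carbon, gives 1210 nM. Compound 3 `COc1cccc(C(=O)C(CSC(=S)N(C)C)CSC(=S)N(C)C)c1`, which carries a methoxy on an aromatic carbon instead, gives 1240 nM. All three numbers lie close together: a 1.6-fold lower number from compound 1 to compound 2 (0.20 log units; within the scatter), a 1.6-fold lower number from compound 1 to compound 3 (0.19 log units; within the scatter), and a 1.0-fold higher number from compound 2 to compound 3 (0.01 log units; within the scatter). Compound 2 therefore stands on the same footing as the other two, with no gap that this assay can separate from its repeat-to-repeat noise.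

The next compound, compound 4 `CN(C)C(=S)SCC(CSC(=S)N(C)C)C(=O)c1ccc(OCc2ccccc2)cc1`, differs from compound 2 in a single place: benzyloxy in place of fluoro on an aromatic carbon. This is a larger change than any of the three steps already seen, which only swapped hydrogen, fluoro and methoxy on the six-membered aromatic ring of carbon only. Those steps show that such small changes have left the number unchanged within scatter, but none of them introduces a group of this size, so the data give no direct guide to a benzyloxy group. With nothing pointing in either direction, the expectation is that the number for compound 4 stays near that of compound 2, so the estimated step of a 1.0-fold lower number from compound 2 to compound 4 (0.00 log units; within the scatter) is small. Compound 4 is thus expected to give about 1200 nM, with a likely range from 450 nM to 3200 nM. The range is kept wide. Within the data shown here, no measured step covers a change of this size.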

Compound 4, half-maximal inhibitory concentration: 9770 nM
For compound 4 the middle estimate is 8.1-fold (0.91 log units) below the measured one; the whole stated range lies below it.
By their numbers in this assay, from the lowest: compounds 2, 3 and 1 (each within the scatter of the next); then compound 4.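

In this assay the position para to a large group proves sensitive to what sits on it: benzyloxy in place of fluoro gives an 8.1-fold higher number from compound 2 to compound 4 (0.91 log units; beyond the scatter) and benzyloxy in place of hydrogen gives a 5.1-fold higher number from compound 1 to compound 4 (0.70 log units; beyond the scatter) as well. Among these compounds, both steps lie beyond the scatter, whereas every step among compounds 1, 2 and 3 stayed within it, so this is the first change in the set that clearly separates from the noise, and it goes towards weaker inhibition. Nothing measured here explains the rise.

With a single compound carrying benzyloxy, the result cannot show which part of the group goes with the weaker inhibition: the added aromatic ring, the oxygen that links it, or the overall length of the group. Compounds with a phenyl or a benzyl on this carbon, which keep the added ring without the oxygen, or with an ethoxy, which keeps the oxygen without the ring, would begin to separate these parts, and a group such as an amine would test a different kind of substituent at the same position.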